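This account rests on a few compounds, and the source may have more. Where it says the series, first, only, none or still open, it means among the compounds named here.

In a functional assay on KB cells (Homo sapiens) for cytotoxicity (on this read-out higher numbers stand for an effect only at larger amounts of compound and lower numbers for an effect already at smaller amounts), compound 1 `COC1=C(C)C(=O)/C(=C(O)/C=C/c2cccc(OC)c2)C(=O)C1(C)C` gives 2.4 ug/mL, compound 2 `COC1=C(C)C(=O)/C(=C(O)/C=C/c2ccc(C)cc2)C(=O)C1(C)C` gives 1.9 ug/mL, and compound 3 `COC1=C(C)C(=O)/C(=C(O)/C=C/c2ccccc2C)C(=O)C1(C)C` gives 1.6 ug/mL. These three values lie within the scatter of one another, so compound 3 cannot be told apart from the other two. Compound 4 `CCc1ccc(/C=C/C(O)=C2/C(=O)C(C)=C(OC)C(C)(C)C2=O)cc1` differs from compound 3 by one swap: 4-ethylphenyl in place of 2-methylphenyl on a double-bonded chain carbon bound to a double-bonded chain carbon. Three measured steps exchange the substituted phenyl group at this same place: a 1.3-fold lower number from compound 1 to compound 2 (0.10 log units; within the scatter), a 1.5-fold lower number from compound 1 to compound 3 (0.18 log units; within the scatter) and a 1.2-fold lower number from compound 2 to compound 3 (0.07 log units; within the scatter). None of them leaves the scatter, so no step beyond the scatter is expected in this assay here. The expected step is small, a 1.3-fold higher number from compound 3 to compound 4 (0.10 log units; within the scatter). For compound 4 the estimated value is 2 ug/mL, with an expected range from 1.1 ug/mL to 3.6 ug/mL.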

Compound 4, concentration for half-maximal effect: 1.9 ug/mL
Beside the measured number, compound 4's estimate is 1.1-fold (0.02 log units) above it; the measured number falls inside the stated range.
By their numbers in this assay, from the lowest: compounds 3, 2, 4 and 1 (each within the scatter of the next).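

Compound 4 brings a 4-ethylphenyl group to this place, and in this assay all its steps stay within the scatter: a 1.2-fold higher number from compound 3 to compound 4 (0.07 log units; within the scatter), a 1.3-fold lower number from compound 1 to compound 4 (0.10 log units; within the scatter) and no change at the digits printed from compound 2 to compound 4 (within the scatter). The last of these is methyl in place of hydrogen on a saturated chain carbon bound to an aromatic carbon, so this small extension of the group leaves the read-out unchanged at the digits printed. Nothing measured here offers an explanation for this.

As far as these compounds go, whether an amine, a carboxylic acid or a longer chain such as hexyl on the phenyl ring would give a step beyond the scatter remains open.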